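Chlorofluorophenyl change from compound 2 to compound 4

The source may hold more compounds than are shown below. What is called first, only, known or untested is meant among the compounds shown, and "the series" means these compounds.

Values in an ADME assay on FHC cells (Homo sapiens) for cytotoxicity, read by MTT assay, with a stated time of 72 h; on this read-out higher numbers stand for weaker inhibition and lower numbers for stronger inhibition:
- compound 1 `C=CC(=O)Nc1cc2c(Nc3ccc(OCc4cccc(F)c4)c(Cl)c3)ncnc2cc1OCc1cn(CCCCC(=O)NO)nn1`: > 25000 nM
- compound 2 `C=CC(=O)Nc1cc2c(Nc3cccc(Cl)c3F)ncnc2cc1OCc1cn(CCCCC(=O)NO)nn1`: > 25000 nM
- compound 3 `C=CC(=O)Nc1cc2c(Nc3ccc(OCc4cccc(F)c4)c(Cl)c3)ncnc2cc1OCc1cn(CCC(=O)NO)nn1`: > 25000 nM

All three entries are limits of the assay and not numbers. The evidence so far is the limit of > 25000 nM in this assay, at which 3 of the 3 values shown sit. Compound 2 therefore stands only as a limit, and no number places it within the series.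

The change to compound 4 `C=CC(=O)Nc1cc2c(Nc3ccc(F)c(Cl)c3)ncnc2cc1OCc1cn(CCCCC(=O)NO)nn1` is 3-chloro-4-fluorophenyl in place of 3-chloro-2-fluorophenyl on a nitrogen on an aromatic ring. Within the data shown here, the only measured step is a step that the two limits leave unreadable from compound 1 to compound 3. It has no readable size, and it alters the chain bearing the hydroxycarbamoyl group, not the group on that nitrogen, so it gives no direct measure of this change. Compound 1 and compound 2 carry different groups on that nitrogen, and their two values are the same limit.

Among the measured compounds shown here, no step of measurable size is expected in this assay, and no direction can be assigned. This expectation rests on compound 2 at > 25000 nM, which is a limit. The expected change is a step that the limit leaves unreadable from compound 2 to compound 4, which is estimated to lie within the scatter. A report of only a limit is considered the likeliest outcome for the next compound. For compound 4 the estimated value is 30000 nM, with an expected range of 18000 nM to 50000 nM.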

Compound 4, half-maximal inhibitory concentration: > 25000 nM
Compound 4 was reported as a limit; the forecaster's own chance of this, stated with the estimate: 85%; the middle value lies beyond the limit too.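

In this assay compound 4 gives > 25000 nM as a limit and not a number. Its steps from compound 1 and from compound 2 cannot be read, and the series stands at one limit: the limit of > 25000 nM in this assay, at which 4 of the 4 values shown sit.

The compounds shown leave open at what concentration any of them inhibits these cells, and whether either the group on the nitrogen or the chain bearing the hydroxycarbamoyl group changes that concentration.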